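Swapping the Hydroxyindanylamino Group for a Pyridinylaminomethyl Arm

This account rests on a few compounds, and the source may have more. Where it says the series, first, only, none or still open, it means among the compounds named here.

Compound 1 `c1ccc(C2CCCCN2C2CCN(CCCc3c[nH]c4ccc(-n5cnnc5)cc34)CC2)cc1`: 1.9 nM
Compound 2 `O[C@@H]1Cc2ccccc2[C@H]1NC1CCN(CCCc2c[nH]c3ccc(-n4cnnc4)cc23)CC1`: 6.6 nM
Compound 3 `OC[C@H](NC1CCN(CCCc2c[nH]c3ccc(Cn4cncn4)cc23)CC1)c1ccccc1`: 23 nM

In an assay on CHO cells for displacement of a labelled ligand from 5-hydroxytryptamine receptor 1D (Homo sapiens) (on this read-out lower numbers stand for stronger inhibition and higher numbers for weaker inhibition), compound 2 stands second highest of the three numbers. Its gap to compound 1, the lower number, lies beyond the scatter, and so does its gap to compound 3, the higher number. Compound 4 `c1ccc(NCC2CCN(CCCc3c[nH]c4ccc(-n5cnnc5)cc34)CC2)nc1` has not been measured yet. It differs from compound 2 in one place: ((pyridin-2-yl)amino)methyl in place of (2-hydroxy-2,3-dihydro-1H-inden-1-yl)amino on a saturated ring carbon. Among the compounds with values here, no two measured compounds differ in only one place, so the size of this change has no direct precedent. The expectation is a modest step toward a higher number, a 2.3-fold higher number from compound 2 to compound 4 (0.36 log units; beyond the scatter), beyond the scatter. Compound 4 is estimated at 15 nM, with a range from 4 nM to 60 nM.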

Compound 4, half-maximal inhibitory concentration: 1.7 nM
Compound 4: middle estimate off by 8.8-fold (0.95 log units), on the high side; the whole stated range lies above it.
By their numbers in this assay, from the lowest: compounds 4 and 1 (each within the scatter of the next); then compound 2; then compound 3.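

In this assay the swap gives a 3.9-fold lower number from compound 2 to compound 4 (0.59 log units; beyond the scatter) and so moves the number down. At this saturated ring carbon, a low number therefore does not require (2-hydroxy-2,3-dihydro-1H-inden-1-yl)amino with its 2 defined stereocentres: ((pyridin-2-yl)amino)methyl does better with fewer heavy atoms. Nothing shown here explains why this step occurs. On these data alone, the swap changes several features at once, so the feature responsible remains unknown. As far as these compounds go, it also remains open whether a phenyl group in place of the pyridin-2-yl ring, or a longer chain in place of the methyl, would keep the number this low.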